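This account rests on a few compounds, and the source may have more. Where it says the series, first, only, none or still open, it means among the compounds named here.

Measured so far in an ADME assay on Vero cells (Chlorocebus sabaeus) for cytotoxicity, with a stated time of 5 days; a lower number here means a stronger inhibitor, a higher number a weaker inhibitor:
- compound 1 `CC(C)(CO)Nc1nc(N)nc2c1ncn2[C@H]1C[C@H](N=[N+]=[N-])[C@@H](CO)O1`: > 100000 nM
- compound 2 `CN(C)c1nc(N)nc2c1ncn2[C@H]1C[C@H](N=[N+]=[N-])[C@@H](CO)O1`: > 100000 nM

Neither entry is a number, and the data show (the limit of > 100000 nM in this assay, at which 2 of the 2 values shown sit). Compound 2 is known only by its limit of > 100000 nM, so its place cannot be told more closely than that.

The next compound, compound 3 `[N-]=[N+]=N[C@H]1C[C@H](n2cnc3c(NCCO)nc(N)nc32)O[C@@H]1CO`, carries (2-hydroxyethyl)amino in place of dimethylamino on an aromatic carbon. Within the data shown here, one measured step bears on this change, a step that the two limits leave unreadable from compound 1 to compound 2, which is also an exchange of groups on an aromatic carbon. It gives no size to carry over. Compound 1 already bears (1-(hydroxymethyl)-1-methylethyl)amino, the group closest to the incoming one, and its result is the limit of > 100000 nM. The expectation therefore rests on that limit, and no change beyond the scatter is expected in this assay. The estimated move is a step that the limit leaves unreadable from compound 2 to compound 3. A further limit is the most likely report, and any number would be expected near the top of the measured range. For compound 3 the estimate is 120000 nM, with an expected range from 50000 nM to 300000 nM.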

Compound 3, half-maximal inhibitory concentration: > 100000 nM
Compound 3: only a limit was reported; the forecaster's own chance of this, stated with the estimate: 80%; the middle value lies beyond the limit too.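

Compound 3 is likewise known only by a limit in this assay, > 100000 nM. No step among compound 1, compound 2 and compound 3 can be read, and the three results share one limit: the limit of > 100000 nM in this assay, at which 3 of the 3 values shown sit.

The compounds shown leave open whether any of these exchanges on the aromatic carbon changes the result in this assay, and by how much.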